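The source may report more compounds than this note shows. Statements on the series, on what has been measured and on what is new or still open speak of the compounds shown alone.

Compound 1 `CC(C)(C)c1ccc(-c2nnc(SCCCN3CCN(c4ccccc4)CC3)[nH]2)cc1`, compound 2 `Clc1ccc(-c2nnc(SCCCN3CCN(c4cccc(Cl)c4)CC3)[nH]2)cc1` and compound 3 `Clc1ccc(-c2nnc(SCCCN3CCN(c4ncccn4)CC3)[nH]2)cc1` share one core and were tested in a functional assay on MCF7 cells (Homo sapiens) for cytotoxicity, read by MTT assay, with a stated time of 24 h; a higher number here means a weaker inhibitor, a lower number a stronger inhibitor. In this assay compound 1 gives > 300000 nM, which is a limit of the assay and not a number. In this assay compound 2 gives > 300000 nM, again a limit. In this assay compound 3 gives > 300000 nM, also a limit, so compound 3 stands at the edge of what the assay resolves, with no number of its own. Among the compounds with values here, the single step between measured compounds that differ in one place, a step that the two limits leave unreadable from compound 2 to compound 3, cannot be read because of the limit of > 300000 nM in this assay, at which 3 of the 3 values shown sit.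

Compound 4 `Clc1cccc(-c2nnc(SCCCN3CCN(c4ncccn4)CC3)[nH]2)c1` has not yet been measured. It differs from compound 3 by 3-chlorophenyl in place of 4-chlorophenyl on an aromatic carbon. Within the data shown here, no measured step touches this change: the only step, a step that the two limits leave unreadable from compound 2 to compound 3, concerns another position and is itself unreadable. What is known is the limit of > 300000 nM in this assay, at which 3 of the 3 values shown sit, and on that ground no step beyond the scatter is expected; the expected step is a number no higher from compound 3 to compound 4 (the limit leaves the size open). Compound 4 is accordingly estimated at 300000 nM, between 100000 nM and 1000000 nM, and the assay is expected most likely to report it only as a limit.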

Compound 4, half-maximal inhibitory concentration: > 300000 nM
Compound 4: only a limit was reported; the forecaster's own chance of this, stated with the estimate: 85%; the middle value lies on the limit itself.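

Compound 3 and compound 4 both give only a limit in this assay, so the step between them, 3-chlorophenyl in place of 4-chlorophenyl, cannot be read: the limit of > 300000 nM in this assay, at which 4 of the 4 values shown sit.

The compounds shown leave open whether this change makes any difference to cytotoxicity, and how strongly any of the four compounds acts in this assay.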